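From 1H-benzimidazol-2-yl to 1,3-benzoxazol-2-yl in compound 3

The compounds below may be only part of what the source reports. "The series", "measured", "known", "first", "only" and "open" are said of these compounds alone.

compound 1 `N#Cc1nc2c(-c3nc4ccccc4[nH]3)c(N)n(CCO)c2nc1C#N`: > 50000 nM (a limit, not a number)
compound 2 `CCCCn1c(N)c(-c2nc3ccccc3[nH]2)c2nc(C#N)c(C#N)nc21`: > 50000 nM (a limit, not a number)
compound 3 `CCN(CC)CCCCn1c(N)c(-c2nc3ccccc3[nH]2)c2nc(C#N)c(C#N)nc21`: 1550 nM

For the measured compounds named here, in a functional assay on HL60/MX2 cells (Homo sapiens) for antiproliferative activity, read by MTT assay, with a stated time of 48 h (on this read-out lower numbers stand for stronger inhibition and higher numbers for weaker inhibition), compound 3 gives 1550 nM, the only true number here. The other two values stand at the limit of > 50000 nM in this assay, at which 2 of the 3 values shown sit.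

Compound 4 `CCN(CC)CCCCn1c(N)c(-c2nc3ccccc3o2)c2nc(C#N)c(C#N)nc21` changes one group on an aromatic carbon: 1,3-benzoxazol-2-yl in place of 1H-benzimidazol-2-yl on an aromatic carbon. The measured steps all alter the chain instead. Two are large: an at least 32-fold lower number from compound 1 to compound 3 (1.50 log units; beyond the scatter) and an at least 32-fold lower number from compound 2 to compound 3 (1.50 log units; beyond the scatter). The third, a step that the two limits leave unreadable from compound 1 to compound 2, cannot be read. None of them gives a size for this swap. Compound 4 keeps the 4-(diethylamino)butyl group of compound 3, so a value near 1550 nM is expected, with no step beyond the scatter and a slight lean towards a higher number. The estimated step is a 1.6-fold higher number from compound 3 to compound 4 (0.21 log units; within the scatter). The expected value for compound 4 is 2500 nM, within a range of 600 nM to 12000 nM.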

Compound 4, half-maximal inhibitory concentration: 1720 nM
For compound 4 the middle estimate is 1.5-fold (0.16 log units) above the measured one, and the stated range covers the measured number.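

In this assay, putting 1,3-benzoxazol-2-yl in place of 1H-benzimidazol-2-yl gives a 1.1-fold higher number from compound 3 to compound 4 (0.05 log units; within the scatter). For the compounds shown here, this is the first reading at this aromatic carbon rather than on the chain, and with the 4-(diethylamino)butyl group kept, this position accepts an entering group with no hydrogen-bond donor without a change beyond the scatter. Nothing given here explains this result. As far as these compounds go, how a 1,3-benzothiazol-2-yl or a phenyl group would read at this position remains open. So does whether the same swap would read alike with a plain butyl chain.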